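Replacing bromophenyl with nitrophenyl on the aromatic nitrogen

The source may report more compounds than this note shows. Statements on the series, on what has been measured and on what is new or still open speak of the compounds shown alone.

Compound 1, `C/C(=C\CC/C(C)=C/CC[C@@H]1[C@@]2(C)CCC(=O)C(C)(C)[C@H]2CC[C@@]1(C)O)CC/C=C(\C)C(=O)OCc1cn(-c2cccc(O)c2)nn1`, in a functional assay on A549 cells (Homo sapiens) for antiproliferative activity, read by MTT assay, with a stated time of 48 h (a lower number here means a stronger inhibitor, a higher number a weaker inhibitor), gives 42800 nM.
Compound 2, `C/C(=C\CC/C(C)=C/CC[C@@H]1[C@@]2(C)CCC(=O)C(C)(C)[C@H]2CC[C@@]1(C)O)CC/C=C(\C)C(=O)OCc1cn(C[C@@H]2O[C@H](n3ccc(=O)[nH]c3=O)[C@H]3OC(C)(C)O[C@H]32)nn1`, in this assay gives 15300 nM.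
Compound 3, `C/C(=C\CC/C(C)=C/CC[C@@H]1[C@@]2(C)CCC(=O)C(C)(C)[C@H]2CC[C@@]1(C)O)CC/C=C(\C)C(=O)OCc1cn(-c2ccc(Br)cc2)nn1`, in this assay gives > 150000 nM, which is a limit of the assay and not a number.

All three share the same core and differ only in the group carried on the aromatic nitrogen. Compound 3 stands at the weak end of what was measured: it sits at the limit of > 150000 nM in this assay, at which 1 of the 3 values shown sits, so only a bound is known for it. Among the measured compounds shown here, the one measured step that bears on the aryl group is an at least 3.5-fold higher number from compound 1 to compound 3 (0.54 log units; beyond the scatter), which shows that exchanging 3-hydroxyphenyl for 4-bromophenyl raised the number beyond the scatter.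

Compound 4, `C/C(=C\CC/C(C)=C/CC[C@@H]1[C@@]2(C)CCC(=O)C(C)(C)[C@H]2CC[C@@]1(C)O)CC/C=C(\C)C(=O)OCc1cn(-c2cccc([N+](=O)[O-])c2)nn1`, differs from compound 3 as follows: 3-nitrophenyl in place of 4-bromophenyl on an aromatic nitrogen. For the measured compounds named here, no measured step covers 3-nitrophenyl, so the direction of this change is uncertain; the only guide is that the hydroxyphenyl analogue, compound 1, gave a finite number while compound 3 gave a limit. Compound 4 is therefore expected to remain weak in this assay, with its number estimated at 90000 nM, plausibly between 30000 nM and 200000 nM, and the expected step is an at least 1.6-fold lower number from compound 3 to compound 4 (0.22 log units; that floor lies within the scatter).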

Compound 4, half-maximal inhibitory concentration: > 150000 nM
Compound 4: a limit, no number; the forecaster's own chance of this, stated with the estimate: 45%; at least 1.6-fold (0.22 log units) between middle value and limit.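

In this assay compound 4 gives a limit of the assay and not a number, and it now stands with compound 3 at the weak end of the series: the limit of > 150000 nM in this assay, at which 2 of the 4 values shown sit.

Nitro in place of hydroxy on an aromatic carbon gives an at least 3.5-fold higher number from compound 1 to compound 4 (0.54 log units; beyond the scatter), so the 3-nitrophenyl group does not retain the finite reading seen with the 3-hydroxyphenyl group. The earlier step from 3-hydroxyphenyl to 4-bromophenyl changed both the substituent and its place on the phenyl ring; this step changes the substituent alone, which shows that a substituent exchange at the same ring place is enough to produce a change beyond the scatter.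

From the compounds shown here alone, the step between compound 3 and compound 4 cannot be read, as both values are limits, so the order of 4-bromophenyl and 3-nitrophenyl remains unknown. Also open, going by these compounds, is whether an amine or a methoxy group in place of the hydroxy would retain a finite number, and whether a 4-hydroxyphenyl group would do so, which would separate the role of the hydroxy group from that of its place on the ring.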